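A few compounds are considered here, and "the series" means these few. Any claim that something is new, unique, unknown or untested is made for them only; others in the source may bear on it.

Measured compounds:
compound 1 `O[C@@H]1Cc2ccccc2[C@H]1NC1CCN(CCCc2c[nH]c3ccc(-n4cnnc4)cc23)CC1` — 13 nM
compound 2 `c1cc(CNC2CCN(CCCc3c[nH]c4ccc(-n5cnnc5)cc34)CC2)co1` — 7.1 nM
compound 3 `CC(=O)Nc1ccc(CNC2CCN(CCCc3c[nH]c4ccc(-n5cnnc5)cc34)CC2)cc1` — 5 nM

In an assay on CHO cells for agonist activity at 5-hydroxytryptamine receptor 1D (Homo sapiens), read by GTPgammaS binding (on this read-out lower numbers stand for an effect already at smaller amounts and higher numbers for an effect only at larger amounts of compound), compound 1 gives 13 nM, the highest of the three numbers; its gap to compound 2 lies within the scatter, its gap to compound 3 beyond it. Compound 4 `C[C@@H](NC1CCN(CCCc2c[nH]c3ccc(-n4cnnc4)cc23)CC1)c1ccccc1` is not yet measured. Against compound 1 it shows (1-phenylethyl in place of 2-hydroxy-2,3-dihydro-1H-inden-1-yl on an amine nitrogen). Among the compounds with values here, two measured steps bear on this: both also exchange the group on that amine nitrogen. The change to a 1.8-fold lower number from compound 1 to compound 2 (0.26 log units; within the scatter) and the change to a 2.6-fold lower number from compound 1 to compound 3 (0.41 log units; beyond the scatter); between them, a 1.4-fold lower number from compound 2 to compound 3 (0.15 log units; within the scatter). Every exchange of the bicyclic group for a smaller arylmethyl group so far gave a lower number, of small to modest size. The 1-phenylethyl group is of the same kind, so a small step toward a lower number in this assay is expected, possibly within the scatter. Compound 4 is therefore estimated at 7 nM, with a range from 3 nM to 18 nM. The expected step is a 1.9-fold lower number from compound 1 to compound 4 (0.27 log units; within the scatter).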

Compound 4, half-maximal effective concentration: 13 nM
Compound 4: the middle estimate sits 1.9-fold (0.27 log units) below what was measured, within the range that was stated.
By their numbers in this assay, from the lowest: compounds 3, 2, 1 and 4 (each within the scatter of the next, the first and the last beyond it).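

In this assay, 1-phenylethyl in place of 2-hydroxy-2,3-dihydro-1H-inden-1-yl on the amine nitrogen gives no change at the digits printed from compound 1 to compound 4 (within the scatter), so the hydrogen-bond donor and acceptor of the leaving group are lost with no readable change. Against the other groups, 1-phenylethyl gives a 2.6-fold higher number from compound 3 to compound 4 (0.41 log units; beyond the scatter) and a 1.8-fold higher number from compound 2 to compound 4 (0.26 log units; within the scatter), so leaving the 2-hydroxy-2,3-dihydro-1H-inden-1-yl group does not lower the number by itself, and among the groups shown only 4-acetamidobenzyl stands clear of both compound 1 and compound 4. No measurement available here accounts for these steps.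

Open, on these data alone, is whether a plain benzyl group on this nitrogen would read with compound 3 or with compound 4, and whether an amine or a carboxylic acid in place of the acetamido group would keep the number of compound 3. As far as these compounds go, the opposite stereoisomer of the 1-phenylethyl group is equally open.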